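The compounds below may be only part of what the source reports. "The series", "measured", "known", "first", "only" and "open" are said of these compounds alone.

Measured so far:
- compound 1 `Cc1ccccc1Oc1cccc(COc2ccccc2CCC(=O)OCCCOP(=O)(O)OC[C@H](N)C(=O)O)c1` — 0.28
- compound 2 `Cc1cccc(Oc2cccc(COc3ccccc3CCC(=O)OCCCOP(=O)(O)OC[C@H](N)C(=O)O)c2)c1` — 0.29
- compound 3 `CCc1ccc(Oc2cccc(COc3ccccc3CCC(=O)OCCCOP(=O)(O)OC[C@H](N)C(=O)O)c2)cc1` — 0.42

In an assay on cells for activation of probable G-protein coupled receptor 34 (Mus musculus), with a stated time of 1 h (a lower number here means a smaller maximal response, a higher number a larger maximal response), compound 3 gives 0.42, the highest of the three numbers; the nearest, compound 2, gives 0.29, and the furthest, compound 1, gives 0.28, both beyond the scatter below compound 3.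

Compound 4 `CC(C)(C)c1cccc(Oc2cccc(COc3ccccc3CCC(=O)OCCCOP(=O)(O)OC[C@H](N)C(=O)O)c2)c1` has not yet been measured in this assay. It differs from compound 3 in one place: 3-(tert-butyl)phenyl in place of 4-ethylphenyl on an oxygen on an aromatic ring.

Among the measured compounds shown here, two measured steps bear on it. a number 0.010 higher from compound 1 to compound 2 (within the scatter) shows that shifting a methyl from one position of the phenyl to another changes nothing beyond the scatter. a number 0.14 higher from compound 1 to compound 3 (beyond the scatter) and a number 0.13 higher from compound 2 to compound 3 (beyond the scatter) show a modest gain when the small methyl gives way to the larger 4-ethyl. For the measured compounds named here, compound 4 carries a larger group still, but no step shows what a 3-(tert-butyl)phenyl does, so the change of position and the change of size cannot be separated. The expectation in this assay is therefore a step of about a number 0.020 lower from compound 3 to compound 4 (within the scatter), within the scatter, with real uncertainty either way.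

Compound 4 is estimated at 0.4, in the range 0.27 to 0.55.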

Compound 4, intrinsic activity: the largest response reached, as a fraction of the reference agonist's: 0.39
The estimate for compound 4 lay 0.010 above the measured number; low and high end bracket the measured number.
By their numbers in this assay, from the lowest: compounds 1, 2, 4 and 3 (each within the scatter of the next, the first and the last beyond it).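

In this assay, the step a number 0.030 lower from compound 3 to compound 4 (within the scatter) shows that 3-(tert-butyl)phenyl, with 10 heavy atoms, and 4-ethylphenyl, with 8, cannot be told apart on an oxygen on an aromatic ring. Against the two methyl compounds the reading is split: tert-butyl in place of methyl gives a number 0.10 higher from compound 2 to compound 4 (within the scatter), whereas the change from 2-methylphenyl gives a number 0.11 higher from compound 1 to compound 4 (beyond the scatter), although compound 1 and compound 2 themselves lie within the scatter of each other. Nothing measured on these compounds offers an explanation for these steps.

The share of group size and the share of ring position in these steps remain unseparated, as each larger group here also sits at a different place on the phenyl. On these data alone, how an amine or a carboxylic acid on this phenyl would read also remains open.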